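The compounds below may be only part of what the source reports. "The series", "measured", "known", "first", "only" and "open" are said of these compounds alone.

Working notes on the series. Compound 1 `C#CCN(Cc1ccc2nc(C)nc(O)c2c1)c1cccc(CC)c1` gives 5000 nM in a functional assay on L1210 cells (Mus musculus) for inhibition (a lower number here means a stronger inhibitor, a higher number a weaker inhibitor), the lowest of the numbers in hand. Compound 2 `C#CCN(Cc1ccc2nc(C)nc(O)c2c1)c1cccc(CO)c1` gives 48000 nM in this assay, and the step of a 9.6-fold higher number from compound 1 to compound 2 (0.98 log units; beyond the scatter). Compound 3 `C#CCN(Cc1ccc2nc(C)nc(O)c2c1)c1cccc(C(C)O)c1` returns only a limit in this assay, > 49000 nM. The corresponding step is an at least 9.8-fold higher number from compound 1 to compound 3 (0.99 log units; beyond the scatter). A third step, an at least 1.0-fold higher number from compound 2 to compound 3 (0.00 log units; that floor lies within the scatter), adds nothing beyond that floor. The unmeasured compound 4 `C#CCN(Cc1ccc2nc(C)nc(O)c2c1)c1ccc(C#N)cc1` differs from compound 1 by 4-cyanophenyl in place of 3-ethylphenyl on an amine nitrogen. Among the compounds with values here, no measured step covers this exchange: the two steps in hand both place a hydroxy on the saturated chain carbon of the 3-ethylphenyl, and both push the number higher by modest amounts, the set including (the limit of > 49000 nM in this assay, at which 1 of the 3 values shown sits). The only pattern available is that alterations to this phenyl have moved the number above that of compound 1, so a modest rise is expected here as well, a 3.0-fold higher number from compound 1 to compound 4 (0.48 log units; beyond the scatter), with wide uncertainty. Compound 4 is estimated at 15000 nM, between 3000 nM and 80000 nM.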

Compound 4, half-maximal inhibitory concentration: > 5000 nM
Compound 4 gave a limit, no number; the forecaster's own chance of this, stated with the estimate: 25%; the middle value lies beyond the limit too.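

Within the data shown here, the exchange reaches further than the earlier steps: those altered only the saturated chain carbon of the 3-ethylphenyl, whereas here the whole group on the amine nitrogen gives way to 4-cyanophenyl. Compound 4 gives only a limit in this assay, so the step to it from compound 2 cannot be read in size. Even so, this larger change gives a number no lower from compound 1 to compound 4 (the limit leaves the size open) and so joins the hydroxy changes in that none of the three gives a number below that of compound 1, 5000 nM.

The compounds shown do not separate the nitrile from its place on the phenyl, which 3-cyanophenyl or 4-ethylphenyl on the same amine nitrogen would do. Also open, going by these compounds, is whether any other group here, such as 3-propylphenyl with its longer chain or 3-aminophenyl, would give a lower number than compound 1.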